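Aryl swaps on a triazole that leave activity unchanged

The compounds below may be only part of what the source reports. "The series", "measured", "known", "first", "only" and "open" are said of these compounds alone.

Compound 1 `CCOc1ccccc1-n1nncc1CN1C(=O)C2(C(C#N)=C(N)Oc3c(N)cc4nc5ccccc5nc4c32)c2ccccc21` gives > 50000 nM in a functional assay on HCT-116 cells (Homo sapiens) for antiproliferative activity, read by MTT assay, with a stated time of 48 h (a higher number here means a weaker inhibitor, a lower number a stronger inhibitor), which is a limit of the assay rather than a number.
Compound 2 `Cc1ccc(-n2nncc2CN2C(=O)C3(C(C#N)=C(N)Oc4c(N)cc5nc6ccccc6nc5c43)c3ccccc32)cc1C` gives > 50000 nM in this assay, again only a limit.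
Compound 3 `N#CC1=C(N)Oc2c(N)cc3nc4ccccc4nc3c2C12C(=O)N(Cc1cnnn1-c1cc(Cl)ccc1Cl)c1ccccc12` gives > 50000 nM in this assay, also a limit.

Compound 3 therefore stands where the other two stand: the limit of > 50000 nM in this assay, at which 3 of the 3 values shown sit, collects all three measured values. Compound 4 `N#CC1=C(N)Oc2c(N)cc3nc4ccccc4nc3c2C12C(=O)N(Cc1cnnn1-c1ccc(F)c(Cl)c1)c1ccccc12` differs from compound 3 by 3-chloro-4-fluorophenyl in place of 2,5-dichlorophenyl on an aromatic nitrogen. Among the measured compounds shown here, the steps that bear on this change, a step that the two limits leave unreadable from compound 1 to compound 2, a step that the two limits leave unreadable from compound 1 to compound 3 and a step that the two limits leave unreadable from compound 2 to compound 3, cannot be sized, since each value is a limit. No direction beyond the scatter can be read from them. Compound 4 is therefore expected to give 60000 nM in this assay, within 15000 nM to 200000 nM, meaning an expected step that the limit leaves unreadable from compound 3 to compound 4.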

Compound 4, half-maximal inhibitory concentration: > 50000 nM
Compound 4 ended at the assay's limit; the forecaster's own chance of this, stated with the estimate: 80%; the middle value is on the limit's open side.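

Like compound 1, compound 2 and compound 3, compound 4 sits at a limit, so none of its steps to those three can be read. The compounds shown leave open whether any aryl group on the triazole gives a readable value in this assay.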